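Flipping one stereocentre of compound 1

This account rests on a few compounds, and the source may have more. Where it says the series, first, only, none or still open, it means among the compounds named here.

Measured in an ADME assay on Akata cells (Homo sapiens) for cytotoxicity; on this read-out lower numbers stand for higher toxicity in this test and higher numbers for lower toxicity in this test
compound 1 `Nc1ncnc2c1ncn2/C=C1/C[C@H]1[C@H](O)CO` gives 93500 nM
compound 2 `Nc1nc2c(ncn2/C=C2/C[C@H]2[C@H](O)CO)c(=O)[nH]1` gives 62600 nM
compound 3 `Nc1nc2c(ncn2/C=C2/C[C@H]2[C@@H](O)CO)c(=O)[nH]1` gives 78000 nM

Compound 1 lies within the usual scatter of both compound 2 and compound 3, so these three numbers cannot be ranked. Compound 4 `Nc1ncnc2c1ncn2/C=C1/C[C@H]1[C@@H](O)CO` is built from compound 1 by one change (the two compounds have the same atoms and bonds and differ only in configuration as drawn: 1 of 3 stereo elements differ; a stereocentre at a saturated chain carbon is drawn S in compound 1 and R in compound 4). Compound 2 and compound 3 form the matching pair, with the same kind of change at that stereocentre, and their step is small (a 1.2-fold higher number from compound 2 to compound 3 (0.10 log units; within the scatter)). In this assay no step beyond the scatter is therefore expected, in either direction, and the estimated 1.0-fold higher number from compound 1 to compound 4 (0.01 log units; within the scatter) (within the scatter) reflects that. For compound 4 the estimate is 95000 nM (expected range 55000 nM to 165000 nM).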

Compound 4, half-maximal cytotoxic concentration: 61500 nM
The estimate for compound 4 lay 1.5-fold (0.19 log units) above the measured number, and the stated range covers the measured number.
By their numbers in this assay, from the lowest: compounds 4, 2, 3 and 1 (each within the scatter of the next).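

In this assay, the flip from S to R at the saturated chain carbon can now be read in a second pair of compounds (a 1.5-fold lower number from compound 1 to compound 4 (0.18 log units; within the scatter)). Among the compounds shown here, the only earlier reading of this change came from the other pair (a 1.2-fold higher number from compound 2 to compound 3 (0.10 log units; within the scatter)). Both steps lie within the scatter, so the two drawn configurations at this stereocentre cannot be told apart by this read-out in either pair. From the compounds shown here alone, it remains open whether an amine or a carboxylic acid in place of the chain's hydroxyl, or a longer chain, would move the number beyond the scatter, and whether the configuration at this carbon would then matter.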